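Anilinoquinazoline sulfonamide amides: aryl swap at the amine

A few compounds are considered here, and "the series" means these few. Any claim that something is new, unique, unknown or untested is made for them only; others in the source may bear on it.

Compound 2 `COc1ccc(Nc2ncnc3cc(OC)c(OCCCCC(=O)Nc4ccc(S(N)(=O)=O)cc4)cc23)cc1OC` is the only fully measured point beside compound 1 `COc1cc2ncnc(Nc3ccc(Br)cc3)c2cc1OCCCCC(=O)Nc1ccc(S(N)(=O)=O)cc1` in this set. In a functional assay on A549 cells (Homo sapiens) for antiproliferative activity, read by MTT assay, with a stated time of 72 h (on this read-out higher numbers stand for weaker inhibition and lower numbers for stronger inhibition), compound 2 gives only a limit of > 40000 nM. Compound 1 likewise gives only a limit in this assay, > 40000 nM. Among the measured compounds shown here, the one measured step, a step that the two limits leave unreadable from compound 1 to compound 2, is therefore unreadable in size and direction, as both values sit at the same limit (the limit of > 40000 nM in this assay, at which 2 of the 2 values shown sit). Where compound 2 stands on the numbers shown is thus simply the limit itself; nothing here separates it from compound 1.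

Compound 3 `COc1cc2ncnc(Nc3ccc(C(F)(F)F)cc3)c2cc1OCCCCC(=O)Nc1ccc(S(N)(=O)=O)cc1` differs from compound 2 by 4-(trifluoromethyl)phenyl in place of 3,4-dimethoxyphenyl on a nitrogen on an aromatic ring. For the measured compounds named here, the only measured step that bears on this site, the one from compound 1 to compound 2, carries no readable size, so no expectation of a step in this assay beyond the scatter can be drawn from it in either direction. The estimate for compound 3 is accordingly set at the same limit as compound 2: an expected value of 40000 nM, with a range from 12000 nM to 130000 nM, which corresponds to an expected step of a number no higher from compound 2 to compound 3 (the limit leaves the size open) and most likely again only a limit rather than a number.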

Compound 3, half-maximal inhibitory concentration: 14800 nM
Compound 3: the middle estimate sits 2.7-fold (0.43 log units) above what was measured; low and high end bracket the measured number.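

Notes on the aryl group on the amine nitrogen: in this assay, this is the first place in the set where a change moves the read-out off the limit, so the group here is not silent, which compound 1 and compound 2 alone could not show. 4-(Trifluoromethyl)phenyl in place of 3,4-dimethoxyphenyl gives an at least 2.7-fold lower number from compound 2 to compound 3 (0.43 log units; beyond the scatter), and trifluoromethyl in place of bromo on an aromatic carbon gives an at least 2.7-fold lower number from compound 1 to compound 3 (0.43 log units; beyond the scatter). Both sizes are lower bounds only, and compound 3 is the one compound here with a number: the limit of > 40000 nM in this assay, at which 2 of the 3 values shown sit.

From the compounds shown here alone, the step between compound 1 and compound 2 cannot be read, so nothing orders those two, and with a single numbered compound it remains open whether the gain belongs to trifluoromethyl itself or would also come with other groups. Also open, going by these compounds, is what a nitrile or an amine on the same phenyl ring would give in this assay, and whether a shorter chain linking the core to the amide would shift the read-out.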